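Moving the hydroxyl on the pendant phenyl ring

This account rests on a few compounds, and the source may have more. Where it says the series, first, only, none or still open, it means among the compounds named here.

Measured so far:
- compound 1 `Oc1ccc(-c2cc(-c3cccs3)cc(-c3ccc(O)cc3)n2)cc1`: 2190 nM
- compound 2 `Oc1ccc(-c2cc(-c3ccco3)cc(-c3ccccc3O)n2)cc1`: > 50000 nM
- compound 3 `Oc1ccc(-c2cc(-c3ccco3)cc(-c3cccc(O)c3)n2)cc1`: 2070 nM

In a functional assay on DU-145 cells (Homo sapiens) for cytotoxicity, read by CCK-8 assay (on this read-out higher numbers stand for weaker inhibition and lower numbers for stronger inhibition), compound 3 gives 2070 nM, the lowest of the two numbers in hand. Compound 1 gives 2190 nM in this assay, which sits within the scatter of compound 3, so no order between the two can be claimed. For compound 2 this assay reports only a limit, > 50000 nM, and not a number (the limit of > 50000 nM in this assay, at which 1 of the 3 values shown sits).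

Within the data shown here, the one measured step on the same aromatic carbon, an at least 24-fold lower number from compound 2 to compound 3 (1.38 log units; beyond the scatter), shows that the hydroxyl position on that phenyl ring can matter a great deal when moved from the 2-position to the 3-position.

Compound 4 `Oc1ccc(-c2cc(-c3ccco3)cc(-c3ccc(O)cc3)n2)cc1` is not yet measured. The change from compound 3 is 4-hydroxyphenyl in place of 3-hydroxyphenyl on an aromatic carbon. Among the measured compounds shown here, no measured step covers the move from 3-hydroxyphenyl to 4-hydroxyphenyl, so the large step from compound 2 to compound 3 does not transfer directly. Compound 1, which carries a 4-hydroxyphenyl at this place with a thiophen-2-yl group elsewhere, gives a value within the scatter of compound 3, so the expected change is small.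

Compound 4 is therefore expected to give about 2100 nM in this assay, within 700 nM to 6500 nM, corresponding to an estimated step of a 1.0-fold higher number from compound 3 to compound 4 (0.01 log units; within the scatter), which is not expected to go beyond the scatter.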

Compound 4, half-maximal inhibitory concentration: > 50000 nM
Compound 4 was reported as a limit (the forecaster's own chance of this, stated with the estimate: 5%); at least 23-fold (1.37 log units) between middle value and limit.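

Moving the hydroxyl from 3-hydroxyphenyl to 4-hydroxyphenyl at this place, next to the ring nitrogen, gives an at least 24-fold higher number from compound 3 to compound 4 (1.38 log units; beyond the scatter) in this assay, so among the furan-2-yl compounds shown, only the 3-hydroxyphenyl compound has a readable number. Compound 4 is reported only as a limit, as is compound 2, so the step between these two cannot be read: the limit of > 50000 nM in this assay, at which 2 of the 4 values shown sit. Furan-2-yl in place of thiophen-2-yl gives an at least 22-fold higher number from compound 1 to compound 4 (1.35 log units; beyond the scatter), so with 4-hydroxyphenyl held constant, the outcome depends on the other aromatic substituent as well, and compound 1 goes against any reading that 4-hydroxyphenyl alone rules out a readable number.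

The compounds shown leave open whether the preference for 3-hydroxyphenyl over 4-hydroxyphenyl also holds with thiophen-2-yl on the core, since no thiophen-2-yl partner of compound 3 is among them. They also leave open whether the hydroxyl itself is required, as a methoxy group or an amine at the same ring position would be needed to separate the role of the hydroxyl from that of its placement.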